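A few compounds are considered here, and "the series" means these few. Any claim that something is new, unique, unknown or untested is made for them only; others in the source may bear on it.

Within the data shown here, in a functional assay on the whole organism with Rattus norvegicus as the target (a higher number here means that more compound is needed for the effect, a lower number that less compound is needed), compound 1 `C[Si](C)(C)c1ccc2nc(N)sc2c1` gives 5 mg/kg, the only exact number so far. Compound 2 `Nc1nc2ccc(C3CCCCC3)cc2s1` has only a limit, > 10 mg/kg. Compound 3 `CCC(C)(C)c1ccc2nc(N)sc2c1` keeps the core of compound 1 and changes one group on an aromatic carbon, where a 1,1-dimethylpropyl group replaces the group containing silicon: a group of 5 heavy atoms (5 carbon; no ring) in place of a group of 4 heavy atoms (3 carbon, 1 silicon; no ring), on an aromatic carbon. Among the measured compounds shown here, no measured pair tests this replacement, so the step of a 1.2-fold higher number from compound 1 to compound 3 (0.08 log units; within the scatter) is expected to stay within the usual scatter, with no firm direction. In this assay, compound 3 is estimated at 6 mg/kg, with an expected range from 2.5 mg/kg to 14 mg/kg.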

Compound 3, dose for half-maximal effect: > 10 mg/kg
Compound 3: no number, only a limit (the forecaster's own chance of this, stated with the estimate: 25%); at least 1.6-fold (0.22 log units) between middle value and limit.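

In this assay, replacing the group containing silicon with 1,1-dimethylpropyl on this aromatic carbon gives an at least 2.0-fold higher number from compound 1 to compound 3 (0.30 log units; that floor lies within the scatter). Going by these compounds, compound 3 has only a limit, so this step is a floor and its true size remains unknown. The comparison is therefore coarse: the limit of > 10 mg/kg in this assay, at which 2 of the 3 values shown sit. The compounds shown leave open how a tert-butyl group, a methoxy group or a chlorine atom on this aromatic carbon would read in this assay. They also leave open what changes on the amine of the shared core would do.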